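A New Ring on the Oxygen

The source may hold more compounds than are shown below. What is called first, only, known or untested is meant among the compounds shown, and "the series" means these compounds.

Of the compounds shown here, three have been tested so far in a functional assay on NCI-H460 cells (Homo sapiens) for cytotoxicity, read by MTT assay, with a stated time of 96 h; a lower number here means a stronger inhibitor, a higher number a weaker inhibitor. Compound 1 `COc1ncc(-c2cc3c(C)nc(N)nc3n([C@H]3CC[C@H](OCCO)CC3)c2=O)cc1NS(=O)(=O)c1ccc(F)cc1F` gives 360 nM, compound 2 `COc1ncc(-c2cc(OC)c3nc(N)nc(C)c3c2)cc1NS(=O)(=O)c1ccc(F)cc1F` gives 280 nM, and compound 3 `COc1ncc(-c2cc(OC3CCCCC3)c3nc(N)nc(C)c3c2)cc1NS(=O)(=O)c1ccc(F)cc1F` gives 96 nM. That makes compound 3 the strongest inhibitor of the three, with compound 2 nearest to it and compound 1 furthest away.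

Among the measured compounds shown here, the next compound, compound 4 `COc1ncc(-c2cc(OCC3CCOCC3)c3nc(N)nc(C)c3c2)cc1NS(=O)(=O)c1ccc(F)cc1F`, has no measurement yet. It has (oxan-4-yl)methyl in place of cyclohexyl on an oxygen on an aromatic ring.

For the measured compounds named here, the one measured step at this oxygen is a 2.9-fold lower number from compound 2 to compound 3 (0.46 log units; beyond the scatter), with cyclohexyl in place of methyl. In that single pair, the cyclohexyl group went with the lower number, which is too little to call a pattern. Going by the values given here, compound 4 keeps a six-membered non-aromatic ring, but no measured compound shows what a hetero atom in that ring does here.

Compound 3 at 96 nM is therefore the nearest guide, and the expected result is a 1.5-fold higher number from compound 3 to compound 4 (0.16 log units; within the scatter), a small rise that is not expected to clear the scatter. Compound 4 is estimated at 140 nM, with an expected range of 55 nM to 340 nM.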

Compound 4, half-maximal inhibitory concentration: 21 nM
For compound 4 the middle estimate is 6.7-fold (0.82 log units) above the measured one; the whole stated range lies above it.
By their numbers in this assay, from the lowest: compound 4; then compound 3; then compounds 2 and 1 (each within the scatter of the next).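

The oxygen position still had more to give after cyclohexyl: in this assay the switch to (oxan-4-yl)methyl brought a further drop (a 4.6-fold lower number from compound 3 to compound 4 (0.66 log units; beyond the scatter)), even though both groups hold a six-membered non-aromatic ring. Measured against the methyl group, the same side group gives the largest step seen so far at this oxygen (a 13-fold lower number from compound 2 to compound 4 (1.12 log units; beyond the scatter)), so the choice of group here can shift the number by much more than the first pair suggested. The change from cyclohexyl adds a ring oxygen, which counts as a hydrogen-bond acceptor, and also adds a carbon, but no measurement here explains why the number fell.

Those two parts of the change remain tangled, and the open comparisons are cyclohexylmethyl, which would keep the added carbon without the ring oxygen, and oxan-4-yl set directly on the oxygen, which would keep the ring oxygen without the added carbon. Also open, as far as these compounds go, is whether an amine such as piperidin-4-ylmethyl, with a ring nitrogen in place of the ring oxygen, would follow compound 4 or fall away from it.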